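The compounds below may be only part of what the source reports. "The series", "measured", "known", "first", "only" and "open" are said of these compounds alone.

Of the compounds shown here, two have so far been measured in an assay on isolated protein for inhibition of Aromatase (Homo sapiens), read by fluorescence, using NADPH, with a stated time of 30 min; a lower number here means a stronger inhibitor, a higher number a weaker inhibitor. Compound 1, `N#Cc1ccc2[nH]c(-c3cccnc3)cc2c1`, carries a cyano group on its core, and in this assay compound 1 gives 11500 nM. Compound 2, `Cn1c(-c2ccccc2)cc2cc([N+](=O)[O-])ccc21`, is built differently, with a nitro group and a methyl on the ring nitrogen, and in this assay compound 2 gives 3880 nM. Of these two numbers compound 1 has the higher one, so it is the weaker inhibitor of the pair; its gap to compound 2 lies beyond the usual scatter of repeated measurements.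

Compound 3, `c1cncc(-c2cc3ccccc3[nH]2)c1`, has not yet been measured. It differs from compound 1 in a single place: hydrogen in place of cyano on an aromatic carbon. Among the measured compounds shown here, no step between two measured compounds shows what taking away a cyano group does in this assay, so the expectation rests on compound 1 alone. Starting from the value of compound 1, 11500 nM, the step is estimated as a 1.9-fold higher number from compound 1 to compound 3 (0.28 log units; within the scatter), a modest loss of inhibition. Compound 3 is therefore expected to give about 22000 nM, with a plausible range from 8000 nM to 60000 nM.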

Compound 3, half-maximal inhibitory concentration: 3050 nM
Beside the measured number, compound 3's estimate is 7.2-fold (0.86 log units) above it; measured number below the stated range.
By their numbers in this assay, from the lowest: compounds 3 and 2 (each within the scatter of the next); then compound 1.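

Taking the cyano group off this aromatic carbon and leaving hydrogen there gives a 3.8-fold lower number from compound 1 to compound 3 (0.58 log units; beyond the scatter) in this assay, so at this position the compound without the nitrile is the stronger inhibitor. Among the compounds shown here, this is the first direct reading of a single change, and it shows that, for this pair, the cyano group adds no inhibition over plain hydrogen; instead, the pair loses inhibition when it is present. The data shown offer no measurement that explains why this swap lowers the number.

From the compounds shown here alone, only cyano has been compared with hydrogen at this position, so it remains open whether a fluorine atom, a methoxy group, an amine or a carboxylic acid on the same aromatic carbon would also weaken inhibition, or whether the loss is particular to cyano. Compound 2 differs from compound 3 in more than one place, so what its nitro group and the methyl on its ring nitrogen each contribute on their own cannot be read from these compounds.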